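Trimming a side chain on a quinolone ether

The compounds below may be only part of what the source reports. "The series", "measured", "known", "first", "only" and "open" are said of these compounds alone.

Compound 1 `COC(C)(C)CCOc1cccc(OCc2[nH]c3ccccc3c(=O)c2C)c1` was tested in an in vitro ADME assay on microsomes from liver (Mus musculus) for metabolic stability, tested at 0.2 uM; on this read-out higher numbers stand for fast clearance and lower numbers for slow clearance. In this assay compound 1 gives only a limit, > 1000 mL/min/kg, not a number. Compound 2 `Cc1c(COc2cncc(OCCC(C)(C)O)c2)[nH]c2ccccc2c1=O` shares the core and gives 225 mL/min/kg. For compound 3 `Cc1ccc2[nH]c(COc3cccc(OCC4CCOCC4)c3)c(C)c(=O)c2c1` the result in this assay is "not determined" (no result reported). Among the values shown, compound 1 stands at the edge of what can be measured, because it sits at the limit of > 1000 mL/min/kg in this assay, at which 1 of the 3 values shown sits. Compound 4 `CCCCOc1cccc(OCc2[nH]c3ccccc3c(=O)c2C)c1` has not been measured; it differs from compound 1 by one change: ethyl in place of 1-methoxy-1-methylethyl on a saturated chain carbon, two bonds along the chain from an oxygen on an aromatic ring. With an ethyl in place of the 1-methoxy-1-methylethyl, the expected step from compound 1 to compound 4 is an at least 1.1-fold lower number from compound 1 to compound 4 (0.04 log units; that floor lies within the scatter), hardly beyond the scatter. Compound 4 is therefore estimated at 900 mL/min/kg, between 350 mL/min/kg and 2500 mL/min/kg.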

Compound 4, clearance: > 1000 mL/min/kg
Compound 4 was reported as a limit; the forecaster's own chance of this, stated with the estimate: 45%; middle value at least 1.1-fold (0.04 log units) away from the limit.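

Among the compounds shown here, compound 1 and compound 4 are both reported only as limits, not numbers, so no step between them can be read: the limit of > 1000 mL/min/kg in this assay, at which 2 of the 4 values shown sit.

The compounds shown leave open how fast either compound is actually cleared, and whether trimming the side chain changes that at all.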